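Diisopropylamino for Diethylamino on a Thiocarbonyl Carbon

The source may hold more compounds than are shown below. What is called first, only, known or untested is meant among the compounds shown, and "the series" means these compounds.

Measured compounds:
compound 1, `CCN(CC)C(=S)SCc1cc(=O)c2ccc(Cl)cc2o1`, 8800 nM in a functional assay on LM7 cells (Homo sapiens) for antiproliferative activity, read by MTT assay, with a stated time of 72 h; on this read-out lower numbers stand for stronger inhibition and higher numbers for weaker inhibition
compound 2, `O=c1c(Cl)c(CSC(=S)N2CCCC2)oc2ccccc12`, 1900 nM

Two compounds carry a dithiocarbamate attached through a thiocarbonyl carbon to the shared core. In this assay compound 1 gives 8800 nM, the highest of the two numbers. In this assay compound 2 gives 1900 nM, a number that sits below that of compound 1 by more than the usual scatter. Compound 1 and compound 2 differ in more than one place, so the two values show only where each one lies and not what any single change does.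

Compound 3, `CC(C)N(C(=S)SCc1cc(=O)c2ccc(Cl)cc2o1)C(C)C`, has not yet been measured. It differs from compound 1 in one place: diisopropylamino in place of diethylamino on a thiocarbonyl carbon. Among the measured compounds shown here, no measured pair shows what this kind of change does on the shared core, and compound 2 offers no help because its 1900 nM belongs to a compound altered elsewhere as well. The step in this assay is therefore expected to be small, most likely within the scatter, with no strong reason to favour either direction; the expected step is a 1.1-fold lower number from compound 1 to compound 3 (0.04 log units; within the scatter). Compound 3 is expected to give about 8000 nM in this assay, within a range from 3000 nM to 25000 nM.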

Compound 3, half-maximal inhibitory concentration: > 30000 nM
Compound 3: only a limit was reported (the forecaster's own chance of this, stated with the estimate: 10%); middle value at least 3.7-fold (0.57 log units) from the limit.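

In this assay, among the compounds shown here, the replacement of diethylamino by diisopropylamino on a thiocarbonyl carbon is the first single change on the shared core that can be read, and it is not neutral: it gives an at least 3.4-fold higher number from compound 1 to compound 3 (0.53 log units; beyond the scatter). Compound 3 is reported only as a limit, > 30000 nM, so this step has a known lower bound but no known size: the limit of > 30000 nM in this assay, at which 1 of the 3 values shown sits. On the core of compound 1, this position therefore does not treat these two amino groups alike, and diisopropylamino carries the weaker result.

From the compounds shown here alone, what remains open is whether a smaller group such as dimethylamino, or a ring amine such as morpholine or piperidine, on the thiocarbonyl carbon would give a lower number than diethylamino on this same core. Compound 2, at 1900 nM, cannot settle this question; it differs from compound 1 in more than one place, so its value cannot be assigned to the amino group alone.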